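Series notes: from compound 3 to compound 4

This account rests on a few compounds, and the source may have more. Where it says the series, first, only, none or still open, it means among the compounds named here.

Among the measured compounds shown here, in a physicochemical assay for solubility, using the shake flask method, in simulated intestinal fluid, measured as kinetic solubility, with a stated time of 2 h, at 25 degrees C, at pH 6.5 (a lower number here means a less soluble compound, a higher number a more soluble compound), three compounds have numbers so far. Compound 1 `CNC(=O)c1nc(C)c2c(c1N)C(=O)N(Cc1ccccc1)C2=O` gives 41000 nM, compound 2 `Cc1noc(-c2nc(C)c3c(c2N)C(=O)N(Cc2ccc(Oc4ccc(F)cc4)cc2)C3=O)n1` gives 23800 nM, and compound 3 `Cc1noc(-c2nc(C)c3c(c2N)C(=O)N(CC2CCOCC2)C3=O)n1` gives 5700 nM. Compound 3 stands lowest of the three, and the gap to each of the other two lies beyond the scatter.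

Next is compound 4 `COc1cccc(CN2C(=O)c3c(C)nc(-c4nc(C)no4)c(N)c3C2=O)c1`, not yet measured. The change is 3-methoxyphenyl in place of oxan-4-yl on a saturated chain carbon bound to an amide-type nitrogen in a ring. For the measured compounds named here, the series offers no measured step that differs in one place, so the size of this step cannot be read directly. Only the three values guide it. Compound 1 and compound 2 both carry an aromatic ring on that chain carbon, and compound 3, the only one without, has the lowest number. Three compounds are a thin basis, and compound 1 also differs elsewhere. The expectation leans on compound 2 at 23800 nM, but only partly: its aromatic group is not 3-methoxyphenyl.

A rise is expected in this assay, and the estimated 2.3-fold higher number from compound 3 to compound 4 (0.36 log units; beyond the scatter) is modest, near the edge of the scatter. For compound 4 the estimate is 13000 nM, with an expected range of 4500 nM to 36000 nM.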

Compound 4, solubility: < 5000 nM
Compound 4 ended at the assay's limit; the forecaster's own chance of this, stated with the estimate: 5%; at least 2.6-fold (0.41 log units) between middle value and limit.
By their numbers in this assay, from the lowest: compound 3; then compounds 2 and 1 (each within the scatter of the next). At a limit, below all of these: compound 4.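

In this assay, the series now has its first step that differs in one place, on a saturated chain carbon bound to an amide-type nitrogen in a ring, with 3-methoxyphenyl in place of oxan-4-yl: an at least 1.1-fold lower number from compound 3 to compound 4 (0.05 log units; that floor lies within the scatter). For compound 4, the reading of < 5000 nM is a limit of the assay and not a number. This change therefore brings no rise at this position, but the size of any fall cannot be fixed, and the stated floor of the step does not clear the scatter, because the reading sits at the limit: the limit of < 5000 nM in this assay, at which 1 of the 4 values shown sits.

The compounds shown leave open how much of this step belongs to the aromatic ring and how much to the methoxy group, a question that plain phenyl on the same chain carbon, with the rest of compound 4 unchanged, would address. Also open, on these data alone, is how an amine or a carboxylic acid at this place would read against compound 3 in this assay, and whether either would give a number clear of the limit.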